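This account rests on a few compounds, and the source may have more. Where it says the series, first, only, none or still open, it means among the compounds named here.

Compound 1 `CCCc1ccc(-c2cc3cn([C@H]4C[C@H](O)[C@@H](CO)O4)c(=O)nc3s2)cc1` is the parent of this pair. In a functional assay on HeLa cells (Homo sapiens) for cytotoxicity (a higher number here means that more compound is tolerated, a lower number that less compound is tolerated), compound 1 gives only a limit, > 200000 nM. Among the compounds with values here, compound 2 `CCCCCCCCc1ccc(-c2cc3cn([C@H]4C[C@H](O)[C@@H](CO)O4)c(=O)nc3s2)cc1` is its one measured neighbour. In this assay compound 2 likewise gives only a limit, > 200000 nM. Within the data shown here, the step that the two limits leave unreadable from compound 1 to compound 2 therefore cannot be read; the sole evidence is the limit of > 200000 nM in this assay, at which 2 of the 2 values shown sit. Compound 3 `CCCCCCCCc1cc2cn([C@H]3C[C@H](O)[C@@H](CO)O3)c(=O)nc2s1` differs from compound 1 by octyl in place of 4-propylphenyl on an aromatic carbon. Among the measured compounds shown here, no measured step covers this change directly; the only step known, a step that the two limits leave unreadable from compound 1 to compound 2, lengthens a chain and stays unreadable, so no size and no direction can be taken from it. On these numbers no step beyond the scatter is expected, and compound 3 is expected to remain at the same limit in this assay. The estimate for compound 3 is 250000 nM, with a range of 100000 nM to 600000 nM. The expected step that the limit leaves unreadable from compound 1 to compound 3 is nominally nil, with a high chance that only a limit is again reported.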

Compound 3, half-maximal cytotoxic concentration: 53000 nM
Compound 3: middle estimate off by 4.7-fold (0.67 log units), on the high side; the measured number lies below the stated range.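

Within the data shown here, on the aromatic carbon next to the ring sulfur, octyl in place of 4-propylphenyl gives the first readable number of the series in this assay, with an at least 3.7-fold lower number from compound 1 to compound 3 (0.57 log units; beyond the scatter). The group at this position can therefore move the tolerated concentration beyond the scatter, which the earlier pair could not show. The step from compound 1 to compound 2 still cannot be read, as both values are limits: the limit of > 200000 nM in this assay, at which 2 of the 3 values shown sit.

The change removes the aromatic ring and brings in the long chain at once, and the compounds shown do not separate these two parts of it. On these data alone, how a butyl chain, a decyl chain or an aminoalkyl group would read at this position in this assay remains open.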